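A few compounds are considered here, and "the series" means these few. Any claim that something is new, unique, unknown or untested is made for them only; others in the source may bear on it.

Measured in a functional assay on CEM-SS cells (Homo sapiens) for cytotoxicity; a lower number here means a stronger inhibitor, a higher number a weaker inhibitor:
- compound 1 `Nc1nc2cc(Cl)c(Cl)cc2n1Cc1cc(C(F)(F)F)cc(C(F)(F)F)c1`: 17000 nM
- compound 2 `FC(F)(F)c1cccc(Cn2c(Br)nc3cc(Cl)c(Cl)cc32)c1`: > 100000 nM

Compound 2 gives only a limit of the assay, > 100000 nM, and not a number.

Compound 3 `FC(F)(F)c1cc(Cn2c(Br)nc3cc(Cl)c(Cl)cc32)cc(C(F)(F)F)c1` departs from compound 2 in one place: trifluoromethyl in place of hydrogen on an aromatic carbon, with trifluoromethyl in place of hydrogen on an aromatic carbon, meta to a trifluoromethyl group. Within the data shown here, no measured step shows this change, so the expectation rests on little. Among the measured compounds shown here, the only firm number in this assay is that of compound 1, 17000 nM, and it suggests that firm numbers can occur here. A modest step towards stronger inhibition is therefore expected in this assay, and compound 3 may still reach the limit. The estimated change is an at least 1.6-fold lower number from compound 2 to compound 3 (0.22 log units; that floor lies within the scatter). For compound 3 the estimated value is 60000 nM, within an expected range of 20000 nM to 100000 nM.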

Compound 3, half-maximal inhibitory concentration: > 100000 nM
Compound 3 ended at the assay's limit; the forecaster's own chance of this, stated with the estimate: 50%; at least 1.6-fold (0.22 log units) between middle value and limit.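

In this assay, a second trifluoromethyl group on the ring of compound 2 leaves compound 3 at the limit as well, and that step cannot be read because both compounds sit at a limit: the limit of > 100000 nM in this assay, at which 2 of the 3 values shown sit.

With both trifluoromethyl groups in place, bromo in place of amino on an aromatic carbon gives the first readable step, an at least 5.8-fold higher number from compound 1 to compound 3 (0.76 log units; beyond the scatter). Among the compounds shown, bromo on the shared core thus goes with the limit, whether one trifluoromethyl group or two is present, and the only firm number belongs to the amino compound.

Going by these compounds, whether trifluoromethyl at this position changes anything when amino is present stays open. So does what a methylamine or a carboxylic acid would give in place of bromo on the shared core.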